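Bromo for methylamino at the five-membered ring carbon

The compounds below may be only part of what the source reports. "The series", "measured", "known", "first", "only" and "open" are said of these compounds alone.

Measured compounds:
Compound 1 `CN(C)c1nc2c(Cl)cc(Cl)cc2n1COC(CO)CO` — in a functional assay on KB cells (Homo sapiens) for inhibition (on this read-out higher numbers stand for weaker inhibition and lower numbers for stronger inhibition), compound 1 gives > 100000 nM, a limit of the assay.
Compound 2 `CNc1nc2c(Cl)c(Cl)ccc2n1COC(CO)CO` — in this assay compound 2 gives > 100000 nM, a limit of the assay.
Compound 3 `OCC(CO)OCn1c(S)nc2c(Cl)cc(Cl)cc21` — in this assay compound 3 gives > 100000 nM, a limit of the assay.

Compound 2 stands at the limit, as do the two other measured compounds; no number separates them (the limit of > 100000 nM in this assay, at which 3 of the 3 values shown sit). Compound 4 `OCC(CO)OCn1c(Br)nc2c(Cl)c(Cl)ccc21` has not been measured in this assay. It differs from compound 2 in one place: bromo in place of methylamino on an aromatic carbon.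

Within the data shown here, the only measured step that changes a group at this carbon is a step that the two limits leave unreadable from compound 1 to compound 3, and it runs between two limits, so its size cannot be read. Among the measured compounds shown here, no measured step bears on the exchange of methylamino for bromo, and no value of the shared core lies below the limit from which a change of direction could be judged.

The expectation for compound 4 therefore rests on the limit of compound 2 alone, and the step of a number no higher from compound 2 to compound 4 (the limit leaves the size open) is estimated as one that cannot be read as a gain. Compound 4 is expected at about 100000 nM, with a range from 20000 nM to 500000 nM, most likely again reported only as a limit.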

Compound 4, half-maximal inhibitory concentration: > 100000 nM
Compound 4 gave a limit, no number; the forecaster's own chance of this, stated with the estimate: 80%; the middle value sits exactly at the limit.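

No step can be read from compound 2 to compound 4 in this assay; both compounds give a limit of the assay and not a number, as do the other compounds shown: the limit of > 100000 nM in this assay, at which 4 of the 4 values shown sit.

The compounds shown leave open whether any group at this carbon, or any other change on the shared core, gives a measurable inhibition value.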